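The compounds below may be only part of what the source reports. "The series", "measured", "known", "first", "only" and "open" are said of these compounds alone.

Measured in a functional assay on HCT-15 cells (Homo sapiens) for cytotoxicity, read by ELISA, with a stated time of 2 days; a higher number here means a weaker inhibitor, a lower number a stronger inhibitor:
- compound 1 `Oc1cccc(-c2cc(-c3ccccc3)cc(-c3cccs3)n2)c1`: 10900 nM
- compound 2 `Oc1cccc(-c2cc(-c3ccccc3)cc(-c3ccco3)n2)c1`: 13500 nM

In this assay compound 2 gives 13500 nM, and it stands level with compound 1, since the two lie within the scatter of each other. Compound 3 `Oc1cccc(-c2cc(-c3ccccc3)cc(-c3ccncc3)n2)c1` has pyridin-4-yl in place of furan-2-yl on an aromatic carbon, next to the ring nitrogen (pyridin-4-yl in place of furan-2-yl on an aromatic carbon). Within the data shown here, only one measured step bears on this change: a 1.2-fold higher number from compound 1 to compound 2 (0.09 log units; within the scatter), with furan-2-yl in place of thiophen-2-yl at that same carbon. That step exchanges one five-membered aromatic ring for another, and no six-membered aromatic ring has yet been measured there, so the guide is weak and no direction can be drawn from it. The expected result in this assay is a 1.0-fold lower number from compound 2 to compound 3 (0.02 log units; within the scatter), which means no step beyond the scatter. For compound 3 the estimated value is 13000 nM, with an expected range from 5000 nM to 35000 nM.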

Compound 3, half-maximal inhibitory concentration: 27400 nM
Estimate against measurement, compound 3: 2.1-fold (0.32 log units) below; the range from low to high includes it.
By their numbers in this assay, from the lowest: compounds 1 and 2 (each within the scatter of the next); then compound 3.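

In this assay, the kind of ring on this carbon turns out to matter, which the exchange between the two five-membered rings had not shown. With pyridin-4-yl in place of furan-2-yl there is a 2.0-fold higher number from compound 2 to compound 3 (0.31 log units; beyond the scatter) and with it in place of thiophen-2-yl there is a 2.5-fold higher number from compound 1 to compound 3 (0.40 log units; beyond the scatter) so the six-membered ring gives the weaker inhibitor in both comparisons, though both steps are modest. Nothing available explains this shift.

As far as these compounds go, whether the shift follows from the six-membered ring itself or from its nitrogen remains open, and a pyridin-3-yl group at this carbon would bear on that question. Also open, from the compounds shown here alone, is how an amine or a longer alkyl chain would behave at this same carbon.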